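The source may report more compounds than this note shows. Statements on the series, on what has been measured and on what is new or still open speak of the compounds shown alone.

In a functional assay on the whole organism (Tail, strain ICR) with Mus musculus as the target, in the tail flick test, with a stated time of 150 min, at a dose of 25 umol/kg by the oral route (a higher number here means a stronger effect of the compound at the dose given, a lower number a weaker effect), three compounds have been measured so far:

compound 1 `NC(=O)CC[C@H](NC(=O)CN(c1ncnc2c1ncn2C1CCCCO1)C1CC1)C(=O)OCc1ccccc1` gives 10.7%;
compound 2 `O=C(O)[C@@H]1CCCN1C(=O)CN(c1nc(Cl)nc2[nH]cnc12)C1CC1` gives 7.29%;
compound 3 `O=C(CN(c1ncnc2c1ncn2C1CCCCO1)C1CC1)N[C@@H](CCC(=O)OCc1ccccc1)C(=O)OCc1ccccc1` gives 14.1%.

Compound 3 holds the highest of these three numbers, yet it sits within the scatter of both compound 1 and compound 2, so none of the three can be called more or less active than another. Among the measured compounds shown here, the only measured pair that differs in a single place is a number 3.4 percentage points higher from compound 1 to compound 3 (within the scatter), a change on a carbonyl carbon that leaves the number essentially where it was.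

Compound 4 `O=C(CN(c1ncnc2c1ncn2C1CCCCO1)C1CC1)NCC(=O)OCc1ccccc1` has not yet been measured. It differs from compound 3 in one place: hydrogen in place of 2-(benzyloxycarbonyl)ethyl on a saturated chain carbon bound to an amide-type nitrogen and a carbonyl carbon. For the measured compounds named here, no measured step touches this part of the molecule, so nothing among the measured compounds speaks directly for or against a shift here. What is known is that every difference seen so far has stayed within the scatter, and the three numbers lie close together. The expected outcome is therefore a number 2.1 percentage points lower from compound 3 to compound 4 (within the scatter), that is, no step beyond the scatter. Compound 4 is expected to give 12% in this assay, with a likely range from 4% to 22%.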

Compound 4, a percentage reported as activity, at one dose (the size of the read-out at that dose, not a potency): 7.26%
The estimate for compound 4 lay 4.7 percentage points above the measured number, within the range that was stated.
By their numbers in this assay, from the lowest: compounds 4, 2, 1 and 3 (each within the scatter of the next).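

In this assay, hydrogen in place of the 2-(benzyloxycarbonyl)ethyl group on the saturated chain carbon bound to an amide-type nitrogen and a carbonyl carbon gives a number 6.8 percentage points lower from compound 3 to compound 4 (within the scatter). Among the compounds shown here, the same swap starting from the 2-carbamoylethyl group gives a number 3.4 percentage points lower from compound 1 to compound 4 (within the scatter), so this position has now been probed for the first time, and at this single dose neither side chain can be told apart from bare hydrogen, even though the 2-(benzyloxycarbonyl)ethyl group brings 12 heavy atoms and an aromatic ring. No measurement at hand offers any explanation for these numbers.

The compounds shown leave open whether any group at this carbon can move the number beyond the scatter, for example a small methyl group or a chain ending in an amine. They also leave open whether the four compounds differ at all, since every number here comes from one dose at one stated time, and all the steps at this position remain within the scatter.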